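Phenyl to Methyl: Expecting a Weaker Analogue

This account rests on a few compounds, and the source may have more. Where it says the series, first, only, none or still open, it means among the compounds named here.

Of the compounds shown here, three sharing one core have been measured in a functional assay for antagonist activity at transient receptor potential cation channel subfamily V member 1 (Homo sapiens); a higher number here means a weaker inhibitor, a lower number a stronger inhibitor. Compound 1 `CC(C)(C)CCc1cc(C(F)(F)F)ccc1CNC(=O)Nc1cccc2[nH]ncc12` gives 4.3 nM. Compound 3 `CC(C)(F)CCc1cc(C(F)(F)F)ccc1CNC(=O)Nc1cccc2[nH]ncc12` gives 6 nM, and the step of a 1.4-fold higher number from compound 1 to compound 3 (0.14 log units; within the scatter) lies within the scatter. Compound 2 `O=C(NCc1ccc(-c2ccccc2)nc1N1CCCCC1)Nc1cccc2[nH]ncc12` gives 14 nM, the highest of the three numbers, beyond the scatter from both compounds 1 and 3. Compound 4 `Cc1ccc(CNC(=O)Nc2cccc3[nH]ncc23)c(N2CCCCC2)n1` has not been measured; it differs from compound 2 by methyl in place of phenyl on an aromatic carbon. Going by the values given here, no measured step tests this kind of change, and the step from compound 1 to compound 3 concerns a different part of the molecule, so the only anchor in this assay is the value of compound 2. For compound 4 the expected step is a 4.3-fold higher number from compound 2 to compound 4 (0.63 log units; beyond the scatter), toward a weaker inhibitor. Compound 4 is therefore estimated at 60 nM, with a range from 15 nM to 250 nM.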

Compound 4, half-maximal inhibitory concentration: 16 nM
The estimate for compound 4 lay 3.8-fold (0.57 log units) above the measured number; measured number inside the range.
By their numbers in this assay, from the lowest: compounds 1 and 3 (each within the scatter of the next); then compounds 2 and 4 (each within the scatter of the next).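

In this assay, methyl in place of phenyl on the aromatic carbon next to the ring nitrogen gives a 1.1-fold higher number from compound 2 to compound 4 (0.06 log units; within the scatter). The inhibitor's potency at this position therefore does not depend on keeping the phenyl ring, since a single methyl carbon serves as well. No supporting data bear on why this is so.

Going by these compounds, it remains open whether an amine, a methoxy group or a longer chain such as propyl would fit here equally well. On these data alone, it is also open whether the same swap would behave alike without the piperidin-1-yl group.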